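This account rests on a few compounds, and the source may have more. Where it says the series, first, only, none or still open, it means among the compounds named here.

In a functional assay (blood) for inhibition, with Homo sapiens as the target (on this read-out higher numbers stand for weaker inhibition and lower numbers for stronger inhibition), compound 2 `Cc1nc2ccc(COc3ccc4c(c3)c(SC(C)(C)C)c(CC(C)(C)C(=O)O)n4Cc3ccc(Cl)cc3)cc2s1` reaches only a limit of the assay, > 3000 nM. Compound 1 `CCCC(Oc1ccc2c(c1)c(SC(C)(C)C)c(CC(C)(C)C(=O)O)n2Cc1ccc(Cl)cc1)c1ccc2ccccc2n1` likewise gives only a limit, > 3000 nM. Both results stand at the same limit (the limit of > 3000 nM in this assay, at which 2 of the 2 values shown sit), so compound 2 cannot be ranked against compound 1. Compound 3 `CC(C)c1csc(COc2ccc3c(c2)c(SC(C)(C)C)c(CC(C)(C)C(=O)O)n3Cc2ccc(Cl)cc2)n1` differs from compound 2 in one place: 4-isopropyl-1,3-thiazol-2-yl in place of 2-methyl-1,3-benzothiazol-6-yl on a saturated chain carbon bound to an oxygen on an aromatic ring. Among the compounds with values here, with no measured step to draw on, no shift beyond the usual scatter is expected in this assay from compound 2 to compound 3, meaning an expected step that the limit leaves unreadable from compound 2 to compound 3. Compound 3 is therefore estimated at 5000 nM, within 1500 nM to 20000 nM, and most likely again reported only as a limit.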

Compound 3, half-maximal inhibitory concentration: > 3000 nM
Compound 3: no number, only a limit; the forecaster's own chance of this, stated with the estimate: 70%; the middle value is on the limit's open side.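

Compound 3, like compound 2, gives only a limit, so no step between them can be read: the limit of > 3000 nM in this assay, at which 3 of the 3 values shown sit.

As far as these compounds go, how strongly compound 1, compound 2 and compound 3 actually inhibit remains open.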